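This account rests on a few compounds, and the source may have more. Where it says the series, first, only, none or still open, it means among the compounds named here.

Series notes. Three compounds have been run in a functional assay on A549 cells (Homo sapiens) for antiproliferative activity, read by MTT assay; on this read-out higher numbers stand for weaker inhibition and lower numbers for stronger inhibition. Compound 1 `COc1ccc(NC(=O)Nc2cccc(CNc3ncnc4ccccc34)c2)cc1` gives 29300 nM in this assay. Compound 2 `COc1cc2ncnc(NCc3cccc(NC(=O)Nc4ccc(C)cc4)c3)c2cc1OC` gives 12900 nM, and compound 3 `COc1ccccc1NC(=O)Nc1cccc(CNc2ncnc3cc(OC)c(OC)cc23)c1` gives 15200 nM. On these three numbers compound 3 stands second highest; compound 2 is nearest and compound 1 furthest, both within the scatter, so no ordering among the three can be read. Within the data shown here, the only single-point step that swaps the group on the amide-type nitrogen is a 1.2-fold higher number from compound 2 to compound 3 (0.07 log units; within the scatter).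

Compound 4 `COc1cc2ncnc(NCc3cccc(NC(=O)Nc4ccc(F)cc4)c3)c2cc1OC` is not yet measured. It differs from compound 3 by 4-fluorophenyl in place of 2-methoxyphenyl on an amide-type nitrogen. Among the measured compounds shown here, the one step that bears on this kind of change, a 1.2-fold higher number from compound 2 to compound 3 (0.07 log units; within the scatter), moved nothing beyond the scatter; compound 1 and compound 2, which differ in more than one place, also show numbers within the scatter of each other and of compound 3. Hence no step beyond the scatter is expected in this assay from compound 3 to compound 4, an estimated 1.1-fold lower number from compound 3 to compound 4 (0.04 log units; within the scatter). For compound 4 the estimate is 14000 nM, with an expected range from 5000 nM to 40000 nM.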

Compound 4, half-maximal inhibitory concentration: 16900 nM
Estimate against measurement, compound 4: 1.2-fold (0.08 log units) below; low and high end bracket the measured number.
By their numbers in this assay, from the lowest: compounds 2, 3, 4 and 1 (each within the scatter of the next, the first and the last beyond it).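

With 4-fluorophenyl in place of 2-methoxyphenyl on the amide-type nitrogen, this assay shows a 1.1-fold higher number from compound 3 to compound 4 (0.05 log units; within the scatter), so this place has now carried a third substituted phenyl group with no step beyond the scatter. Fluoro in place of methyl on an aromatic carbon, a change confined to that one substituent, gives a 1.3-fold higher number from compound 2 to compound 4 (0.12 log units; within the scatter) and also stays within the scatter. No measurement at hand explains the size of these steps.

Still open, as far as these compounds go, is whether an amine or a carboxylic acid on this phenyl ring, or a longer chain in its place, would move the number beyond the scatter. From the compounds shown here alone, the contribution of the core also remains open, as compound 1 differs from each of the other compounds in more than one place.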